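The source may report more compounds than this note shows. Statements on the series, on what has been measured and on what is new or still open speak of the compounds shown alone.

Compound 1 `Brc1ccc(Nc2nc(/C=C/c3ccccc3)nc3ccsc23)cc1`: in a functional assay on L02 cells (Homo sapiens) for inhibition, read by Griess assay, with stated times of 1 h and 24 h (a higher number here means a weaker inhibitor, a lower number a stronger inhibitor), compound 1 gives > 1000000 nM, a limit only.
Compound 2 `Brc1ccc(CNc2nc(/C=C/c3ccccc3)nc3ccsc23)cc1`: compound 2 gives > 1000000 nM, a limit only.
Compound 3 `CNc1nc(/C=C/c2cc(OC)c(OC)c(OC)c2)nc2ccsc12`: compound 3 gives > 1000000 nM, a limit only.

Compound 3 thus stands at the limit of this assay and yields no number. The same holds across the set: the limit of > 1000000 nM in this assay, at which 3 of the 3 values shown sit. Compound 4 `COc1cc(/C=C/c2nc(NCc3ccccc3)c3sccc3n2)cc(OC)c1OC` differs from compound 3 by phenyl in place of hydrogen on a saturated chain carbon bound to a nitrogen on an aromatic ring. Among the measured compounds shown here, the one measured step of a related kind, a step that the two limits leave unreadable from compound 1 to compound 2, is unreadable, since both of its ends are limits, so no size can be taken from it. No readable step therefore bears on this change, and nothing in the values shown points away from the limit. The step of a number no higher from compound 3 to compound 4 (the limit leaves the size open) is accordingly estimated as no change beyond the scatter. Compound 4 is estimated at 1000000 nM, with a range from 300000 nM to 5000000 nM, and is most likely to be reported only as a limit.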

Compound 4, half-maximal inhibitory concentration: > 1000000 nM
Compound 4 gave a limit, no number; the forecaster's own chance of this, stated with the estimate: 85%; the middle value lies on the limit itself.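

Compound 3 and compound 4 both sit at a limit, so no step between them can be read: the limit of > 1000000 nM in this assay, at which 4 of the 4 values shown sit.

The compounds shown leave open whether methylamino or benzylamino makes any difference in this assay, since none of them gives a number.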